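A few compounds are considered here, and "the series" means these few. Any claim that something is new, unique, unknown or untested is made for them only; others in the source may bear on it.

As far as these compounds go, compound 1 `Cc1c(-c2ccc(-c3ccccc3F)cc2)nc2ccc(F)cc2c1C(O)C(F)(F)F` is the starting point, and compound 3 `Cc1c(-c2ccc(-c3ccccc3F)cc2)nc2ccc(F)cc2c1C(=O)NS(C)(=O)=O` is the compound whose result is still open. For the measured compounds named here, in a functional assay on MOLM-13 cells (Homo sapiens) for antiproliferative activity (a lower number here means a stronger inhibitor, a higher number a weaker inhibitor), compound 1 gives 640 nM, the only value here that is a number rather than a limit. Compound 2 `Cc1c(-c2ccc(-c3ccccc3F)cc2)nc2ccc(F)cc2c1-c1nnn[nH]1` carries a 1H-tetrazol-5-yl group in the same position. In this assay compound 2 reaches only the limit > 3000 nM, which is not a number. The step of an at least 4.6-fold higher number from compound 1 to compound 2 (0.67 log units; beyond the scatter) therefore shows weaker inhibition, its full size hidden because of the limit of > 3000 nM in this assay, at which 1 of the 2 values shown sits. Compound 3 differs from compound 1 as follows: (methylsulfonyl)carbamoyl in place of 2,2,2-trifluoro-1-hydroxyethyl on an aromatic carbon. Going by the values given here, the only measured step that bears on this change is an at least 4.6-fold higher number from compound 1 to compound 2 (0.67 log units; beyond the scatter), a replacement of the same group at the same carbon. Compound 3 is therefore expected to inhibit more weakly, with an estimated step of a 4.7-fold higher number from compound 1 to compound 3 (0.67 log units; beyond the scatter). For compound 3 the estimate in this assay is 3000 nM, within a range from 1000 nM to 10000 nM.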

Compound 3, half-maximal inhibitory concentration: 300 nM
Compound 3: the middle estimate sits 10-fold (1.00 log units) above what was measured; the measured number lies below the stated range.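

In this assay, the change at this carbon is not a loss in every case: the (methylsulfonyl)carbamoyl group gives a 2.1-fold lower number from compound 1 to compound 3 (0.33 log units; beyond the scatter). The earlier pair showed only a replacement that weakened inhibition, whereas these compounds show that replacing 2,2,2-trifluoro-1-hydroxyethyl at this carbon can go either way, depending on the group that enters. Compared with the 1H-tetrazol-5-yl group, the same group gives an at least 10-fold lower number from compound 2 to compound 3 (1.00 log units; beyond the scatter), a step whose full size stays hidden: the limit of > 3000 nM in this assay, at which 1 of the 3 values shown sits.

The compounds shown do not tell which part of the (methylsulfonyl)carbamoyl group matters for this gain, or why it appears. A carboxylic acid, a simple primary amide or a phenylsulfonyl version at the same carbon would help separate the contribution of the carbonyl from that of the sulfonyl part.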